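Chloro Added Next to the Pyridine Nitrogen

A few compounds are considered here, and "the series" means these few. Any claim that something is new, unique, unknown or untested is made for them only; others in the source may bear on it.

Measured so far in an assay on U2OS cells for activation of nuclear factor erythroid 2-related factor 2 (Homo sapiens), read by chemiluminescence, with a stated time of 6 h; a lower number here means that less compound is needed, a higher number that more compound is needed for the effect:
Compound 1, `COc1ccc(S(=O)(=O)/C=C/c2ccccn2)cc1`, gives > 10000 nM, which is a limit of the assay.
Compound 2, `COc1ccc(S(=O)(=O)/C=C/c2cccnc2)cc1`, gives > 10000 nM, which is likewise a limit of the assay.

Compound 2 therefore stands at the limit of this assay, and it is not alone there: the limit of > 10000 nM in this assay, at which 2 of the 2 values shown sit. Among the compounds with values here, the single measured step, a step that the two limits leave unreadable from compound 1 to compound 2, cannot be read in size or direction, as both of its ends are limits. No readable step is thus available to guide the next change.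

Compound 3, `COc1ccc(S(=O)(=O)/C=C/c2cccnc2Cl)cc1`, differs from compound 2 by chloro in place of hydrogen on an aromatic carbon. Within the data shown here, the only evidence at hand is that both measured compounds sit at the limit (the limit of > 10000 nM in this assay, at which 2 of the 2 values shown sit), and this gives no basis for expecting a readable gain. Compound 3 is expected to give 10000 nM, with a range from 2500 nM to 40000 nM. That estimate corresponds to an expected step of a number no higher from compound 2 to compound 3 (the limit leaves the size open), and the step is expected to fall within the scatter of this assay, most likely as another limit rather than a number.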

Compound 3, half-maximal effective concentration: 955 nM
Compound 3: middle estimate off by 10-fold (1.02 log units), on the high side; measured number below the stated range.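

In this assay, chloro in place of hydrogen on an aromatic carbon, next to the ring nitrogen, gives an at least 10-fold lower number from compound 2 to compound 3 (1.01 log units; beyond the scatter). A single added heavy atom at this place is thus enough to carry the compound from the limit of the assay to a real number, so this position clearly matters for the read-out, which nothing earlier could show. The earlier compounds gave no number from which any change could be judged, and the step between them cannot be read: the limit of > 10000 nM in this assay, at which 2 of the 3 values shown sit.

On these data alone, what stays open is whether this gain belongs to chloro in particular or would also come with another group on the same carbon, such as fluoro, methyl or an amine, since only hydrogen and chloro are compared here. Also open, as far as these compounds go, is whether chloro would bring a similar gain on the pyridin-2-yl ring of compound 1, where the ring nitrogen stands elsewhere, and so whether the effect depends on the ring it sits on.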